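The compounds below may be only part of what the source reports. "The series", "measured", "known", "first", "only" and "open" are said of these compounds alone.

Measured so far in a functional assay on MCF7 cells (Homo sapiens) for inhibition, read by MTT assay, with a stated time of 48 h (a higher number here means a weaker inhibitor, a lower number a stronger inhibitor), are two compounds:
- compound 1 `CCOC(=O)C1=C(N/C=N/c2nnc(S(N)(=O)=O)s2)Nc2[nH]nc(C)c2C1c1ccc(N(C)C)cc1` gives 34500 nM
- compound 2 `CCOC(=O)C1=C(N/N=C(/Cl)c2ccc([N+](=O)[O-])cc2)Nc2[nH]nc(C)c2C1c1ccc(N(C)C)cc1` gives 52700 nM

Among the measured compounds shown here, compound 2 stands within the scatter of compound 1, the only other compound measured. Compound 3 (`CCOC(=O)C1=C(N/C=N/c2ccc(C)cc2)Nc2[nH]nc(C)c2C1c1ccc(N(C)C)cc1`) has not yet been measured. Its change from compound 2 is a group of 9 heavy atoms (8 carbon, 1 nitrogen; one six-membered aromatic ring of carbon only) in place of a group of 12 heavy atoms (7 carbon, 2 nitrogen, 2 oxygen, 1 chlorine; one six-membered aromatic ring of carbon only), on an amine nitrogen on the otherwise shared structure, and both groups hold one six-membered aromatic ring of carbon only. For the measured compounds named here, the one measured step bearing on this, also a change of group on an amine nitrogen, is a 1.5-fold higher number from compound 1 to compound 2 (0.18 log units; within the scatter) and so no step beyond the scatter is expected in this assay for this change, in either direction. Going by the values given here, no measured compound carries the entering group, so this expectation rests on thin ground. For compound 3 the expected value is 40000 nM with an estimated range from 15000 nM to 90000 nM in this reading. The estimated change is a 1.3-fold lower number from compound 2 to compound 3 (0.12 log units; within the scatter) and is expected to stay within the scatter.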

Compound 3, half-maximal inhibitory concentration: 50500 nM
Beside the measured number, compound 3's estimate is 1.3-fold (0.10 log units) below it, and the stated range covers the measured number.
By their numbers in this assay, from the lowest: compounds 1, 3 and 2 (each within the scatter of the next).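

In this assay the exchange of groups on the amine nitrogen gives a 1.0-fold lower number from compound 2 to compound 3 (0.02 log units; within the scatter) and the exchange on the double-bonded nitrogen gives a 1.5-fold higher number from compound 1 to compound 3 (0.17 log units; within the scatter) in this series. Among the compounds shown here, the three groups at this position, one holding a five-membered aromatic ring with hetero atoms and two holding a six-membered aromatic ring of carbon only, therefore all lie within the scatter of one another, which extends the single earlier step to a group as small as 4-methylphenyl. Nothing at hand explains why these groups do not separate.

As far as these compounds go, it remains open whether a group with no aromatic ring on this nitrogen, such as a morpholine ring or a plain ethyl chain, would stay within the scatter. The compounds shown also do not tell whether any change at this position can produce a step beyond it.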